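Replacing the fluorophenyl sulfone of compound 1

A few compounds are considered here, and "the series" means these few. Any claim that something is new, unique, unknown or untested is made for them only; others in the source may bear on it.

Compound 1 `O=S(=O)(c1ccccc1F)c1cn(C2CCNC2)c2ncccc12`: 100% in a functional assay on HeLa cells for antagonist activity at 5-hydroxytryptamine receptor 6 (Homo sapiens), read by cAMP accumulation and immunoassay; on this read-out higher numbers stand for larger maximal responses and lower numbers for smaller maximal responses
Compound 2 `CN1CCC(n2cc(S(=O)(=O)c3ccccc3F)c3cccnc32)C1`: 69%
Compound 3 `CCN1CCC(n2cc(S(=O)(=O)c3cccc(Cl)c3)c3cccnc32)C1`: 93%

On these three numbers compound 1 stands highest, though its gap to compound 3 lies within the scatter; only compound 2 falls clearly below it, by a number 31 percentage points lower from compound 1 to compound 2 (beyond the scatter) after a methyl in place of hydrogen on an amine nitrogen in a ring. Compound 4 `O=S(=O)(Cc1ccc(Cl)s1)c1cn(C2CCNC2)c2ncccc12` keeps that nitrogen unchanged and alters the sulfonyl side instead: (5-chlorothiophen-2-yl)methyl in place of 2-fluorophenyl on a sulfonyl sulfur. For the measured compounds named here, no measured step touches this position, so the single known step offers no guide to its size. Compound 4 is therefore expected to stay near compound 1, with a step of a number 15 percentage points lower from compound 1 to compound 4 (beyond the scatter) in this assay, and its estimated value is 85%, between 60% and 100%.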

Compound 4, largest response reached (reported as percent of maximum), in percent of the reference or control that the assay uses: 94%
For compound 4 the middle estimate is 9 percentage points below the measured one; the measured number falls inside the stated range.
By their numbers in this assay, from the lowest: compound 2; then compounds 3, 4 and 1 (each within the scatter of the next).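

In this assay, for the compounds shown here, the one step measured at the sulfonyl sulfur is a number 6 percentage points lower from compound 1 to compound 4 (within the scatter). This position therefore accepts a five-membered aromatic ring with a hetero atom, carried on a methyl link, in place of a six-membered carbon ring, with no change beyond the scatter. Nothing available explains this outcome.

From the compounds shown here alone, whether a sulfonyl sulfur carrying a plain methyl, a cyclohexyl or an aminoethyl group would behave alike remains open. So does whether methyl on the ring amine nitrogen would have the same effect alongside (5-chlorothiophen-2-yl)methyl.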